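The compounds below may be only part of what the source reports. "The series", "measured", "known", "first", "only" and "open" are said of these compounds alone.

Working notes on the series, all read in a functional assay on MCF7 cells (Homo sapiens) for inhibition, read by sulforhodamine B assay; a lower number here means a stronger inhibitor, a higher number a weaker inhibitor. Compound 1 `O=C1C(NC2CCCC2)=CC(=O)c2c1nc1n2[C@H]2OC[C@@H](O)[C@H]2OC1`, the cyclopentylamino member, gives > 16000 nM, which is a limit and not a number. Compound 2 `O=C1C(N2CCCCC2)=CC(=O)c2c1nc1n2[C@H]2OC[C@@H](O)[C@H]2OC1`, the piperidin-1-yl member, gives > 8000 nM, also a limit. Compound 3 `O=C1C(N2CCC2)=CC(=O)c2c1nc1n2[C@H]2OC[C@@H](O)[C@H]2OC1`, the azetidin-1-yl member, gives > 16000 nM, again a limit, so its place in the series has no number attached.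

Compound 4 `O=C1C(NC2CC2)=CC(=O)c2c1nc1n2[C@H]2OC[C@@H](O)[C@H]2OC1` keeps the shared core and carries cyclopropylamino in place of azetidin-1-yl on a double-bonded ring carbon. Its amino group is of the same kind as the cyclopentylamino of compound 1, while compound 2 and compound 3 both carry the azetidin-1-yl or piperidin-1-yl type of ring.

Among the measured compounds shown here, three measured steps bear on this change: a step that the two limits leave unreadable from compound 1 to compound 3, a step that the two limits leave unreadable from compound 1 to compound 2 and a step that the two limits leave unreadable from compound 2 to compound 3. None has a readable size, so none supplies a size or a direction to carry over. No step beyond the scatter is therefore expected in this assay, and the expected step is a step that the limit leaves unreadable from compound 3 to compound 4. The estimate for compound 4 is 20000 nM, with an expected range from 7000 nM to 60000 nM, and a report as a limit alone is expected to be likely.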

Compound 4, half-maximal inhibitory concentration: > 16000 nM
Compound 4 ended at the assay's limit (the forecaster's own chance of this, stated with the estimate: 80%); the middle value lies beyond the limit too.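

The result for compound 4 is a limit, as are those of compound 1, compound 2 and compound 3, so the steps to compound 4 from compound 1, compound 2 and compound 3 cannot be read. The compounds shown leave open whether any of these amino groups on the double-bonded ring carbon gives a numerical value in this assay.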